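Secondary Amine Variant on the Pyrazolopyrimidine Antagonist Series

The source may report more compounds than this note shows. Statements on the series, on what has been measured and on what is new or still open speak of the compounds shown alone.

Two members of the series have numbers in an assay on cell membranes for displacement of a labelled ligand from corticotropin-releasing factor receptor 1 (Rattus norvegicus); a higher number here means a weaker inhibitor, a lower number a stronger inhibitor. Compound 1 `CCN(CC)c1nc(C)nc2c(-c3cc(OC)c(OC)cc3Br)c(C)nn12` gives 4.06 nM in this assay. Compound 2 `CCCN(CCC)c1nc(C)nc2c(-c3c(C)cc(OC)cc3OC)c(C)nn12` gives 3.72 nM in this assay. Compound 2 has the lower of the two numbers, but its gap to compound 1 lies within the usual scatter, so the two are not distinguished by these data, and as they differ in more than one place no single step can be read between them.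

Compound 3 `CCC(CC)Nc1nc(C)nc2c(-c3c(C)cc(OC)cc3OC)c(C)nn12` carries one change against compound 2: (pentan-3-yl)amino in place of dipropylamino on an aromatic carbon. The change keeps the chain count close while converting a tertiary amine into a secondary one that brings a hydrogen-bond donor. Within the data shown here, no measured step shows what this kind of exchange does, so nothing in the data points in either direction. The expectation is therefore a step from compound 2 to compound 3 of a 1.2-fold higher number from compound 2 to compound 3 (0.08 log units; within the scatter), that is, none beyond the scatter, with the range widened to allow for an unmeasured kind of change. For compound 3 the estimate in this assay is 4.5 nM, with a range from 1.5 nM to 14 nM.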

Compound 3, half-maximal inhibitory concentration: 5 nM
Estimate against measurement, compound 3: 1.1-fold (0.05 log units) below, within the range that was stated.
By their numbers in this assay, from the lowest: compounds 2, 1 and 3 (each within the scatter of the next).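

Among these compounds, at this position, on an aromatic carbon between two ring nitrogen atoms, (pentan-3-yl)amino in place of dipropylamino gives a 1.3-fold higher number from compound 2 to compound 3 (0.13 log units; within the scatter) in this assay and is the first single-place step, so compound 2 and compound 3 are not distinguished by these data. The site therefore accepts a secondary amine bearing a hydrogen-bond donor, as well as a tertiary amine without one, and the branched chain of the entering group serves as well as the two straight propyl chains at the level of these numbers. No measurement at hand speaks to the reason for this result.

Among the compounds shown here, the single step combines the added hydrogen-bond donor with a new chain shape, so the two cannot be separated; a methyl group on the nitrogen of the (pentan-3-yl)amino group would keep the branched chain without the donor. Also open, going by these compounds, are whether a cyclic amine such as morpholine or a shorter secondary amine such as isopropylamino fits at this position, and whether (pentan-3-yl)amino behaves alike on the bromo-substituted aryl group of compound 1.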